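Compound 1 and its tert-butyl analogue in the writhing test

The compounds below may be only part of what the source reports. "The series", "measured", "known", "first", "only" and "open" are said of these compounds alone.

Compound 1 `O=C(/N=C1\NC2(CCCCO2)CCS1)c1ccc(Cl)cc1` gives 1.1 mg/kg in a functional assay on the whole organism (strain CF-1) with Mus musculus as the target, in the writhing test, with a stated time of 15 min; on this read-out higher numbers stand for an effect only at larger amounts of compound and lower numbers for an effect already at smaller amounts. Compound 2 `O=C(/N=C1\NC2(CCCCO2)CCS1)c1ccc([N+](=O)[O-])cc1` gives 28 mg/kg in this assay, and the step of a 25-fold higher number from compound 1 to compound 2 (1.41 log units; beyond the scatter) leaves compound 1 at the lower of the two numbers. Compound 3 `CC(C)(C)C(=O)/N=C1\NC2(CCCCO2)CCS1` differs from compound 1 by tert-butyl in place of 4-chlorophenyl on a carbonyl carbon. Going by the values given here, no measured step covers this change; the only known step, a 25-fold higher number from compound 1 to compound 2 (1.41 log units; beyond the scatter), shows that a change on the carbonyl side can move the number far. A rise beyond the scatter is therefore expected for compound 3 in this assay, by the step of a 4.5-fold higher number from compound 1 to compound 3 (0.66 log units; beyond the scatter). Compound 3 is estimated at 5 mg/kg, within a range from 1.5 mg/kg to 30 mg/kg.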

Compound 3, dose for half-maximal effect: 200 mg/kg
For compound 3 the middle estimate is 40-fold (1.60 log units) below the measured one, outside the stated range (above it).
By their numbers in this assay, from the lowest: compound 1; then compound 2; then compound 3.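

Tert-butyl in place of 4-chlorophenyl on the carbonyl carbon gives a 180-fold higher number from compound 1 to compound 3 (2.26 log units; beyond the scatter), a larger step than the nitro change, a 25-fold higher number from compound 1 to compound 2 (1.41 log units; beyond the scatter). The position therefore responds not only to a change on the aromatic ring but also to the loss of that ring: compound 3, the only compound shown without it, has the highest number. Nothing available explains the size of this step. The compounds shown leave open how a plain phenyl or a cyclohexyl on the carbonyl carbon would read, so the separate contributions of the ring and the chloro remain unresolved.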